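The source may hold more compounds than are shown below. What is called first, only, known or untested is meant among the compounds shown, and "the series" means these compounds.

Measured so far in a functional assay on Lu1 cells (Homo sapiens) for cytotoxicity, read by sulforhodamine B assay; on this read-out lower numbers stand for an effect already at smaller amounts and higher numbers for an effect only at larger amounts of compound:
Compound 1 `C=C1CC[C@@H]2[C@](C)(CO[Si](C)(C)C(C)(C)C)[C@H](OC(C)=O)CC[C@@]2(C)[C@@H]1C/C=C1/C(=O)OC[C@H]1OC(C)=O` gives 2.92 uM.
Compound 2 `C=C1CC[C@@H]2[C@](C)(CO[Si](C)(C)C(C)(C)C)[C@H](O)CC[C@@]2(C)[C@@H]1C/C=C1/C(=O)OC[C@H]1OC(C)=O` gives 10.4 uM.

Compound 2 stands at the higher of these two numbers, and its distance from compound 1 lies beyond the usual scatter of repeated measurements. Compound 3 `C=C1CC[C@@H]2[C@](C)(CO[Si](C)(C)C(C)(C)C)[C@H](O)CC[C@@]2(C)[C@@H]1C/C=C1/C(=O)OC[C@H]1O` has not yet been measured. It differs from compound 2 in one place: hydrogen in place of acetyl on an oxygen on a saturated carbon. For the measured compounds named here, one measured step bears on this change. That step, a 3.6-fold higher number from compound 1 to compound 2 (0.55 log units; beyond the scatter), also replaced an acetyl with hydrogen on an oxygen on a saturated carbon, and it pushed the number up by a modest but clear amount. The same kind of exchange in compound 3 is therefore expected to move the number in the same direction, toward a weaker effect. The expected step is a 2.9-fold higher number from compound 2 to compound 3 (0.46 log units; beyond the scatter). Compound 3 is thus estimated at 30 uM, within a range from 12 uM to 80 uM.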

Compound 3, concentration for half-maximal effect: 48.8 uM
The estimate for compound 3 lay 1.6-fold (0.21 log units) below the measured number, within the range that was stated.
By their numbers in this assay, from the lowest: compound 1; then compound 2; then compound 3.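

In this assay, the change from acetoxy to hydroxy at this second place gives a 4.7-fold higher number from compound 2 to compound 3 (0.67 log units; beyond the scatter) and so repeats the direction of the earlier exchange, which gave a 3.6-fold higher number from compound 1 to compound 2 (0.55 log units; beyond the scatter) at another oxygen. In both steps shown, losing an acetyl raises the number by a modest amount beyond the scatter, and compound 3, which carries no acetyl at all, has the highest number of the three. Nothing measured here explains why the number rises.

The compounds shown leave open what a butyryl ester, a methyl ether or an amine would do at this place, since only acetyl and hydrogen appear on this oxygen. For the compounds shown here, they also leave open whether this exchange would have the same size with the other acetyl still present, as it is seen only with that oxygen already a hydroxy.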